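The source may report more compounds than this note shows. Statements on the series, on what has been measured and on what is new or still open speak of the compounds shown alone.

Three compounds of the series share one core and differ only in the group on the amine nitrogen of the six-membered ring. Compound 1 `O=C(c1ccccn1)N1CCC(NS(=O)(=O)c2cc(S(=O)(=O)c3ccccc3)ccc2C(F)(F)F)CC1` gives 230 nM in an assay on U2OS cells for inhibition of secreted frizzled-related protein 1 (Homo sapiens), read by a luciferase reporter, with a stated time of 18 h; a higher number here means that more compound is needed for the effect, a lower number that less compound is needed. Compound 2 `O=S(=O)(NC1CCN(S(=O)(=O)c2ccccc2)CC1)c1cc(S(=O)(=O)c2ccccc2)ccc1C(F)(F)F` gives 210 nM in this assay. Compound 3 `CC(C)(O)CCN1CCC(NS(=O)(=O)c2cc(S(=O)(=O)c3ccccc3)ccc2C(F)(F)F)CC1` gives 630 nM in this assay, the highest number of the three, beyond the scatter from both others. The steps that lead to compound 3 run the same way: a 2.7-fold higher number from compound 1 to compound 3 (0.44 log units; beyond the scatter) and a 3.0-fold higher number from compound 2 to compound 3 (0.48 log units; beyond the scatter), whereas a 1.1-fold lower number from compound 1 to compound 2 (0.04 log units; within the scatter). Compound 4 `O=C([C@H]1CCNC1)N1CCC(NS(=O)(=O)c2cc(S(=O)(=O)c3ccccc3)ccc2C(F)(F)F)CC1` differs from compound 3 in that ((pyrrolidin-3-yl)carbonyl in place of 3-hydroxy-3-methylbutyl on an amine nitrogen in a ring). The change puts a carbonyl back on the amine nitrogen in the ring, as in compound 1, so the step from compound 1 to compound 3 and the step from compound 2 to compound 3 bear on it; both were modest and beyond the scatter. For the measured compounds named here, a step of comparable size toward a lower number is expected, with added uncertainty since no measured compound carries a (pyrrolidin-3-yl) group; the expected step is a 2.5-fold lower number from compound 3 to compound 4 (0.40 log units; beyond the scatter). Compound 4 is therefore estimated at 250 nM, with a range from 90 nM to 700 nM.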

Compound 4, half-maximal effective concentration: 700 nM
Estimate against measurement, compound 4: 2.8-fold (0.45 log units) below, and the stated range covers the measured number.
By their numbers in this assay, from the lowest: compounds 2 and 1 (each within the scatter of the next); then compounds 3 and 4 (each within the scatter of the next).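

Placing a carbonyl on the amine nitrogen in the ring does not by itself keep the number low in this assay: pyrrolidin-3-yl in place of pyridin-2-yl on a carbonyl carbon gives a 3.0-fold higher number from compound 1 to compound 4 (0.48 log units; beyond the scatter), so the group on that carbonyl also counts at this position. (Pyrrolidin-3-yl)carbonyl and 3-hydroxy-3-methylbutyl are not separated, with a 1.1-fold higher number from compound 3 to compound 4 (0.05 log units; within the scatter), while phenylsulfonyl stays apart from the new group, with a 3.3-fold higher number from compound 2 to compound 4 (0.52 log units; beyond the scatter). No measurement at hand explains these differences.

The compounds shown leave open whether the higher number goes with the pyrrolidine nitrogen or with the ring as a whole; a cyclopentylcarbonyl group, with carbon in place of that nitrogen, would separate the two. From the compounds shown here alone, the opposite configuration at the stereocentre of the pyrrolidin-3-yl group also remains open.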